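From 2,3,4-trimethoxyphenyl to 2-chloro-4-fluorophenyl: an open step

The compounds below may be only part of what the source reports. "The series", "measured", "known", "first", "only" and "open" are said of these compounds alone.

Going by the values given here, in a functional assay on PC-3 cells (Homo sapiens) for cytotoxicity, read by MTT assay, with a stated time of 72 h (on this read-out higher numbers stand for weaker inhibition and lower numbers for stronger inhibition), compound 2 `COc1ccc(/C=C/C(=O)Nc2cc3c(Nc4ccc(F)c(Cl)c4)ncnc3cc2O[C@H]2CCOC2)c(OC)c1OC` gives 7670 nM, the lower of the two numbers so far, while compound 1 `O=C(/C=C/c1ccc([N+](=O)[O-])cc1)Nc1cc2c(Nc3ccc(F)c(Cl)c3)ncnc2cc1O[C@H]1CCOC1` gives 22800 nM. Compound 3 `O=C(/C=C/c1ccc(F)cc1Cl)Nc1cc2c(Nc3ccc(F)c(Cl)c3)ncnc2cc1O[C@H]1CCOC1` carries 2-chloro-4-fluorophenyl in place of 2,3,4-trimethoxyphenyl on a double-bonded chain carbon bound to a double-bonded chain carbon. Among the compounds with values here, the only measured step at this place is modest, a 3.0-fold lower number from compound 1 to compound 2 (0.47 log units; beyond the scatter), and no measured compound carries the entering group. A step beyond the scatter in this assay is therefore not expected, only a slight lean toward a higher number. The expected step is a 1.3-fold higher number from compound 2 to compound 3 (0.12 log units; within the scatter). For compound 3 the estimate is 10000 nM, with an expected range from 3500 nM to 30000 nM.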

Compound 3, half-maximal inhibitory concentration: 7150 nM
Estimate against measurement, compound 3: 1.4-fold (0.15 log units) above, within the range that was stated.
By their numbers in this assay, from the lowest: compounds 3 and 2 (each within the scatter of the next); then compound 1.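

In this assay, putting 2-chloro-4-fluorophenyl in place of 2,3,4-trimethoxyphenyl on a double-bonded chain carbon bound to a double-bonded chain carbon gives a 1.1-fold lower number from compound 2 to compound 3 (0.03 log units; within the scatter), so these two differently substituted phenyl groups cannot be told apart here. Set against 4-nitrophenyl, the entering group gives a 3.2-fold lower number from compound 1 to compound 3 (0.50 log units; beyond the scatter), which leaves the 4-nitrophenyl compound alone apart from the other two. Nothing measured here accounts for this. Going by these compounds, whether a phenyl ring bearing an amine or a carboxylic acid would read differently at this place remains open. So does the effect of replacing the phenyl ring with cyclohexyl.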